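A Bromo-Fluorophenyl Variant in an Antiproliferative Series

The source may report more compounds than this note shows. Statements on the series, on what has been measured and on what is new or still open speak of the compounds shown alone.

Three compounds share one core and differ only in the ring attached to an aromatic nitrogen. In a functional assay on HT-29 cells (Homo sapiens) for antiproliferative activity, read by MTT assay, with a stated time of 72 h (a higher number here means a weaker inhibitor, a lower number a stronger inhibitor), compound 1 `O=C(Nc1ccc(Oc2ccnc3[nH]ccc23)cc1)c1cc2cccnc2n(-c2ccccc2)c1=O` gives 290 nM. In this assay compound 2 `O=C(Nc1ccc(Oc2ccnc3[nH]ccc23)cc1)c1cc2cccnc2n(-c2ccc(Cl)cc2)c1=O` gives 280 nM, and compound 3 `O=C(Nc1ccc(Oc2ccnc3[nH]ccc23)cc1)c1cc2cccnc2n(-c2ccc(F)c(Cl)c2)c1=O` gives 560 nM. Compound 2 has the lowest of the three numbers, but the two steps that touch it are a 1.0-fold lower number from compound 1 to compound 2 (0.02 log units; within the scatter) and a 2.0-fold higher number from compound 2 to compound 3 (0.30 log units; within the scatter), so none of the three is separated from the others beyond the scatter.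

Compound 4 `O=C(Nc1ccc(Oc2ccnc3[nH]ccc23)cc1)c1cc2cccnc2n(-c2ccc(Br)cc2F)c1=O` is not yet measured. Its change from compound 2 is 4-bromo-2-fluorophenyl in place of 4-chlorophenyl on an aromatic nitrogen. Going by the values given here, two measured steps bear on this: adding a chloro to the phenyl, a 1.0-fold lower number from compound 1 to compound 2 (0.02 log units; within the scatter), and swapping to a 3-chloro-4-fluorophenyl, a 2.0-fold higher number from compound 2 to compound 3 (0.30 log units; within the scatter). Both halogen changes on this ring left the number within the scatter, so a further halogen rearrangement is expected to give at most a small step in this assay, perhaps slightly upward, as a 1.4-fold higher number from compound 2 to compound 4 (0.15 log units; within the scatter). Compound 4 is therefore estimated at 400 nM, with a range from 150 nM to 1100 nM.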

Compound 4, half-maximal inhibitory concentration: 2360 nM
Estimate against measurement, compound 4: 5.9-fold (0.77 log units) below; measured number above the stated range.
By their numbers in this assay, from the lowest: compounds 2, 1 and 3 (each within the scatter of the next); then compound 4.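

In this assay compound 4 separates from the rest, with an 8.4-fold higher number from compound 2 to compound 4 (0.93 log units; beyond the scatter) alongside an 8.1-fold higher number from compound 1 to compound 4 (0.91 log units; beyond the scatter) and a 4.2-fold higher number from compound 3 to compound 4 (0.62 log units; beyond the scatter) as its steps to the other three. Going by these compounds alone, the ring on the aromatic nitrogen therefore does matter to this read-out: the changes among compound 1, compound 2 and compound 3 stayed within the scatter and suggested a tolerant position, but the 4-bromo-2-fluorophenyl ring is the first to move the number beyond it. No measurement shown here accounts for this step.

The 4-bromo-2-fluorophenyl ring differs from the 4-chlorophenyl ring in two ways at once, so the compounds shown cannot tell whether the bromine, the fluorine or the pair carries the step. Also open, as far as these compounds go, is how this ring would fare with a non-halogen group such as a methoxy or an amine.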